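Quinone to hydroquinone side chain on a shared core

The source may hold more compounds than are shown below. What is called first, only, known or untested is meant among the compounds shown, and "the series" means these compounds.

Measured so far:
compound 1 `COC1=CC(=O)C=C(C[C@H]2[C@]3(C)CC[C@@H]4[C@]5(CCC[C@]4(C)C(=O)OC5)[C@H]3CC[C@]2(C)O)C1=O` — 1 ug/mL
compound 2 `C[C@@]12CC[C@@H]3[C@]4(CCC[C@]3(C)C(=O)OC4)[C@H]1CC[C@](C)(O)[C@H]2CC1=CC(=O)C=CC1=O` — 7 ug/mL

In a functional assay on MDA-MB-231 cells (Homo sapiens) for inhibition (on this read-out lower numbers stand for stronger inhibition and higher numbers for weaker inhibition), compound 2 gives 7 ug/mL, the higher of the two numbers; its nearest neighbour is compound 1, which gives 1 ug/mL. Among the measured compounds shown here, the single measured step runs a 7.0-fold higher number from compound 1 to compound 2 (0.85 log units; beyond the scatter), a loss of potency that is beyond the scatter.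

Compound 3 `C[C@@]12CC[C@@H]3[C@]4(CCC[C@]3(C)C(=O)OC4)[C@H]1CC[C@](C)(O)[C@H]2Cc1cc(O)ccc1O` differs from compound 2 by a group of 8 heavy atoms (6 carbon, 2 oxygen; one six-membered aromatic ring of carbon only) in place of a group of 8 heavy atoms (6 carbon, 2 oxygen; one six-membered non-aromatic ring of carbon only), on a saturated chain carbon bound to a saturated ring carbon. For the measured compounds named here, no measured step bears on this exchange: the one step known, a 7.0-fold higher number from compound 1 to compound 2 (0.85 log units; beyond the scatter), concerns only the methoxy and leaves the ring type untouched. Going by the values given here, with the direction of the series so far running toward weaker inhibition on removal of a group from the side chain, and with no direct precedent, a modest further weakening is taken as the expectation, with wide uncertainty in both directions.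

Compound 3 is therefore estimated at 15 ug/mL in this assay, within a range of 4 ug/mL to 50 ug/mL. The expected step is a 2.1-fold higher number from compound 2 to compound 3 (0.33 log units; beyond the scatter).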

Compound 3, half-maximal inhibitory concentration: 7 ug/mL
Estimate against measurement, compound 3: 2.1-fold (0.33 log units) above; low and high end bracket the measured number.
By their numbers in this assay, from the lowest: compound 1; then compounds 2 and 3 (each within the scatter of the next).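

In this assay, the ring exchange on the saturated chain carbon gives no change at the digits printed from compound 2 to compound 3 (within the scatter), so this read-out does not separate the non-aromatic ring of compound 2 from the 2,5-dihydroxyphenyl group of compound 3, although only the latter carries hydrogen-bond donors. The step of a 7.0-fold higher number from compound 1 to compound 3 (0.85 log units; beyond the scatter) places compound 1 apart from compound 3 as well, and among these three compounds only compound 1 carries a methoxy group on the side-chain ring. No measurement at hand gives a reason for either result.

As far as these compounds go, whether a methoxy group on the 2,5-dihydroxyphenyl ring would bring compound 3 to the level of compound 1 remains open. Also open, from the compounds shown here alone, is how an amine or a carboxylic acid on that ring would read in this assay.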